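The compounds below may be only part of what the source reports. "The series", "measured", "known", "first", "only" and "open" are said of these compounds alone.

In a functional assay on THP-1 cells (Homo sapiens) for inhibition, read by sulforhodamine B assay, with a stated time of 48 h (a higher number here means a weaker inhibitor, a lower number a stronger inhibitor), compound 1 `COC(=O)[C@@]1(C)C[C@@H](c2coc3ccc(Br)cc3c2=O)N(c2ccccc2)O1` gives 14700 nM, the lowest of the three numbers recorded. Compound 2 `O=c1c([C@@H]2C[C@H](c3ccccc3)ON2c2ccccc2)coc2ccc(F)cc12` gives 54700 nM in this assay, and compound 3 `O=c1c([C@@H]2C[C@H](c3ccccc3)ON2c2ccccc2)coc2ccc(Br)cc12` gives 60000 nM. Compound 2 and compound 3 share one core and differ only in that (fluoro in place of bromo on an aromatic carbon); this change produced a 1.1-fold lower number from compound 3 to compound 2 (0.04 log units; within the scatter). How the core of compound 1 differs from that of compound 3 is not broken down here. Compound 4 `COC(=O)[C@@]1(C)C[C@@H](c2coc3ccc(F)cc3c2=O)N(c2ccccc2)O1`, not yet measured, is obtained from compound 1 by the same change: fluoro in place of bromo on an aromatic carbon. Because the same change gave a 1.1-fold lower number from compound 3 to compound 2 (0.04 log units; within the scatter), the expected step is a 1.1-fold lower number from compound 1 to compound 4 (0.02 log units; within the scatter). Compound 4 is therefore estimated at 14000 nM in this assay, with a likely range from 7000 nM to 28000 nM.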

Compound 4, half-maximal inhibitory concentration: 47000 nM
Beside the measured number, compound 4's estimate is 3.4-fold (0.53 log units) below it; measured number above the stated range.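

In this assay, fluoro in place of bromo on the core of compound 1 gave a 3.2-fold higher number from compound 1 to compound 4 (0.50 log units; beyond the scatter), so this change is not neutral on that core. The step did not carry over in size from one core to the other: the same change on two cores in this assay, a 1.1-fold lower number (0.04 log units; within the scatter) from compound 3 to compound 2 and a 3.2-fold higher number (0.50 log units; beyond the scatter) from compound 1 to compound 4, 3.5-fold (0.54 log units) apart, beyond the scatter of two such steps. This rests on a single pair for each core, so it does not show how the change would behave on any further core, nor which difference between the cores lies behind the gap.

From the compounds shown here alone, how chloro, methoxy or an amine would fare in place of the halogen remains open. So does the effect of a carboxylic acid or an amide in place of the ester of compound 1 and compound 4.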